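A few compounds are considered here, and "the series" means these few. Any claim that something is new, unique, unknown or untested is made for them only; others in the source may bear on it.

Working notes on the series. Compound 1 `COc1ccc(-c2cc(/C=C/C(=O)c3ccc(N)cc3)[nH]n2)cc1` carries an aminophenyl ketone on the shared core. In a functional assay on MDA-MB-231 cells (Homo sapiens) for inhibition, read by MTT assay, with a stated time of 48 h (on this read-out lower numbers stand for stronger inhibition and higher numbers for weaker inhibition), compound 1 gives 1700 nM, the lowest of the two numbers available. The other measured member, compound 2 `COc1cc(-c2cc(/C=C/C(C)=O)[nH]n2)cc(OC)c1OC`, differs from compound 1 in more than one place; in this assay compound 2 gives 27300 nM, and the gap between the two values lies beyond the scatter. Among the measured compounds shown here, no single-place step between measured compounds is available, so the move to compound 3 `COc1ccc(-c2cc(/C=C/C(=O)c3ccc(N)cc3)[nH]n2)cc1OC` rests on the change itself: methoxy in place of hydrogen on an aromatic carbon, on an aromatic carbon of a six-membered aromatic ring of carbon only, ortho to a methoxy group and meta to a large group. For the measured compounds named here, with no comparable measured step, the expected change from compound 1 is small and not beyond the scatter in either direction, a 1.1-fold lower number from compound 1 to compound 3 (0.05 log units; within the scatter). Compound 3 is therefore estimated at 1500 nM in this assay, with a range from 500 nM to 4500 nM.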

Compound 3, half-maximal inhibitory concentration: 2200 nM
Beside the measured number, compound 3's estimate is 1.5-fold (0.17 log units) below it, within the range that was stated.
By their numbers in this assay, from the lowest: compounds 1 and 3 (each within the scatter of the next); then compound 2.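

In this assay the series now has its first single-place step, methoxy in place of hydrogen on an aromatic carbon, ortho to a methoxy group and meta to a large group: a 1.3-fold higher number from compound 1 to compound 3 (0.11 log units; within the scatter) and so no change that can be told from the scatter. This position therefore takes a methoxy group without a measurable effect on this read-out, and compound 1 and compound 3 cannot be ranked. No data at hand bear on why this step is so small.

On these data alone, whether an ethoxy group, a hydroxyl group or a fluorine atom on the same aromatic carbon would also stay within the scatter remains open. Also open, as far as these compounds go, is what a dimethylamino group or a carboxylic acid would do in place of the amine on the aminophenyl ketone.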